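Pyridin-3-yl for dimethoxyphenyl on a TRPV1 antagonist core

The source may report more compounds than this note shows. Statements on the series, on what has been measured and on what is new or still open speak of the compounds shown alone.

Measured compounds:
compound 1 `COc1ccc(CSc2cc(C(F)(F)F)ccc2CNC(=O)C(C)c2ccc(NS(C)(=O)=O)c(F)c2)cc1`, 2.3 nM
compound 2 `CC(C(=O)NCc1ccc(C(F)(F)F)cc1Cl)c1ccc(NS(C)(=O)=O)c(F)c1`, 4 nM
compound 3 `COc1ccc(-c2cc(C(F)(F)F)ccc2CNC(=O)C(C)c2ccc(NS(C)(=O)=O)c(F)c2)cc1OC`, 8.6 nM

Three propanamides sharing one core were measured in an assay on CHO cells for antagonist activity at transient receptor potential cation channel subfamily V member 1 (Homo sapiens), read by FLIPR; on this read-out higher numbers stand for weaker inhibition and lower numbers for stronger inhibition. Compound 3 stands highest: a 2.2-fold higher number from compound 2 to compound 3 (0.33 log units; beyond the scatter) and a 3.7-fold higher number from compound 1 to compound 3 (0.57 log units; beyond the scatter) are both beyond the scatter, while a 1.7-fold higher number from compound 1 to compound 2 (0.24 log units; within the scatter) is not. Compound 4 `CC(C(=O)NCc1ccc(C(F)(F)F)cc1-c1cccnc1)c1ccc(NS(C)(=O)=O)c(F)c1` differs from compound 3 by pyridin-3-yl in place of 3,4-dimethoxyphenyl on an aromatic carbon. Within the data shown here, the steps that bear on it are those into compound 3, where a bulky aryl group in place of chloro or of the sulfanyl group raised the number modestly; pyridin-3-yl keeps an aryl group but with fewer heavy atoms, so compound 4 is expected to sit near compound 3 or somewhat lower, a 1.4-fold lower number from compound 3 to compound 4 (0.16 log units; within the scatter), with an estimated 6 nM (range 2 nM to 20 nM).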

Compound 4, inhibition constant: 59.4 nM
Estimate against measurement, compound 4: 9.9-fold (1.00 log units) below; measured number above the stated range.
By their numbers in this assay, from the lowest: compounds 1 and 2 (each within the scatter of the next); then compound 3; then compound 4.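

In this assay, among these compounds, the earlier compounds showed aryl groups at this position, ortho to a large group, costing little, but the ring itself proves to matter: pyridin-3-yl is clearly poorer than 3,4-dimethoxyphenyl (a 6.9-fold higher number from compound 3 to compound 4 (0.84 log units; beyond the scatter)). The loss is large against chloro (a 15-fold higher number from compound 2 to compound 4 (1.17 log units; beyond the scatter)) and against (4-methoxybenzyl)sulfanyl (a 26-fold higher number from compound 1 to compound 4 (1.41 log units; beyond the scatter)). Nothing at hand accounts for this.

The compounds shown leave open whether the rise follows the ring nitrogen or the absence of the methoxy groups. A plain phenyl group at this position would help separate the two.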